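Silylmethyl in place of dimethylaminomethyl on the enone

This account rests on a few compounds, and the source may have more. Where it says the series, first, only, none or still open, it means among the compounds named here.

Measured so far:
compound 1 `CC(=O)OC/C1=C/C[C@](C)(CCC=C(C)C)/C=C/[C@@H](OC(=O)C=C(C)C)[C@](C)(OC(C)=O)/C=C/C1=O` gives 3520 nM
compound 2 `CC(C)=CCC[C@]1(C)/C=C/[C@@H](OC(=O)C=C(C)C)[C@](C)(O)/C=C/C(=O)/C(CN(C)C)=C\C1` gives 480 nM

Both compounds were tested in a functional assay on SW480 cells (Homo sapiens) for antiproliferative activity, read by MTT assay, with a stated time of 48 h; a lower number here means a stronger inhibitor, a higher number a weaker inhibitor. Compound 2 stands at the lowest of the two numbers; its nearest neighbour is compound 1, which differs from it in several places and shows a number well beyond the scatter, so the two values cannot be tied to a single structural change.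

The next compound, compound 3 `CC(C)=CCC[C@]1(C)/C=C/[C@@H](OC(=O)C=C(C)C)[C@](C)(O)/C=C/C(=O)/C(C[Si](C)(C)C(C)(C)C)=C\C1`, differs from compound 2 in one place:
a group of 7 heavy atoms (6 carbon, 1 silicon; no ring) in place of a group of 3 heavy atoms (2 carbon, 1 nitrogen; no ring), on a saturated chain carbon bound to a double-bonded ring carbon

Among the measured compounds shown here, no step between measured compounds covers a change of this kind, and nothing among the measured compounds shows how a silicon-bearing group at this position behaves. For the measured compounds named here, the expectation rests only on the observation that compound 2, carrying the dimethylamino group, gives 480 nM, the lowest number seen, and that the one compound without it, compound 1, gives 3520 nM. On that basis a step towards a higher number is expected from compound 2 to compound 3 , a 3.1-fold higher number from compound 2 to compound 3 (0.49 log units; beyond the scatter), of moderate size, beyond the scatter. Compound 3 is therefore estimated at 1500 nM, with a range from 400 nM to 6000 nM.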

Compound 3, half-maximal inhibitory concentration: 3350 nM
Compound 3: the middle estimate sits 2.2-fold (0.35 log units) below what was measured; measured number inside the range.
By their numbers in this assay, from the lowest: compound 2; then compounds 3 and 1 (each within the scatter of the next).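

In this assay, the step at this position reads a 7.0-fold higher number from compound 2 to compound 3 (0.84 log units; beyond the scatter), the first reading tied to a single structural change in the series, and it shows that the group on a saturated chain carbon bound to a double-bonded ring carbon is not indifferent to the antiproliferative read-out. The change is not a clean one: dimethylamino, with 3 heavy atoms and 1 hydrogen-bond acceptor, gives way to a group of 7 heavy atoms with 0 hydrogen-bond acceptors, so size, atom type and acceptor count all shift within this one step. No measurement on hand bears on what lies behind the step.

The compounds shown leave open whether the nitrogen itself matters or only the group as a whole, a question that a tert-butyl group, with carbon in place of silicon, or a larger amine such as diethylamino or morpholine at the same place would help to separate. They also leave open whether this step holds on other versions of the shared core, since it rests on a single pair in a single assay.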